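Side-chain changes: from compound 3 to compound 4

This account rests on a few compounds, and the source may have more. Where it says the series, first, only, none or still open, it means among the compounds named here.

Compound 1 `NCCOc1ccc([C@H]2CC[C@]3(CC2)OOC2(O3)C3CC4CC(C3)CC2C4)cc1`: > 100 ug/mL (a limit of the assay)
Compound 2 `CC(C)(O)CN1CCC(Oc2ccc([C@H]3CC[C@]4(CC3)OOC3(O4)C4CC5CC(C4)CC3C5)cc2)CC1`: 1.6 ug/mL
Compound 3 `c1cc([C@H]2CC[C@]3(CC2)OOC2(O3)C3CC4CC(C3)CC2C4)ccc1OCC1CCNCC1`: 12.5 ug/mL

In a physicochemical assay for solubility, read by nephelometry, measured as kinetic solubility, with a stated time of 30 min (on this read-out lower numbers stand for lower solubility and higher numbers for higher solubility), compound 3 holds the higher of the two true numbers at 12.5 ug/mL. The entry for compound 1 is a limit.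

Compound 4 `O[C@H]1CC[C@H](NCCCOc2ccc([C@H]3CC[C@]4(CC3)OOC3(O4)C4CC5CC(C4)CC3C5)cc2)CC1` is next. Its difference from compound 3 is 2-((4-hydroxycyclohexyl)amino)ethyl in place of piperidin-4-yl on a saturated chain carbon bound to an oxygen on an aromatic ring. This places 2-((4-hydroxycyclohexyl)amino)ethyl in place of piperidin-4-yl on a saturated chain carbon bound to an oxygen on an aromatic ring.

Three measured steps alter this side chain: an at least 8.0-fold lower number from compound 1 to compound 3 (0.90 log units; beyond the scatter), an at least 62-fold lower number from compound 1 to compound 2 (1.79 log units; beyond the scatter) and a 7.8-fold higher number from compound 2 to compound 3 (0.89 log units; beyond the scatter). They run in both directions, and none makes the same replacement, so they fix no direction for the new step. They do show that side-chain changes can move this assay well beyond the scatter, so a wide range is warranted. No step beyond the scatter is expected, and the estimate is a 1.1-fold higher number from compound 3 to compound 4 (0.05 log units; within the scatter). Compound 4 is expected at 14 ug/mL, within an estimated range of 3 ug/mL to 60 ug/mL.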

Compound 4, solubility: > 100 ug/mL
Compound 4: a limit, no number; the forecaster's own chance of this, stated with the estimate: 8%; at least 7.1-fold (0.85 log units) between middle value and limit.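

In this assay compound 4 sits at a limit of the assay: the limit of > 100 ug/mL in this assay, at which 2 of the 4 values shown sit. At this place, on a saturated chain carbon bound to an oxygen on an aromatic ring, 2-((4-hydroxycyclohexyl)amino)ethyl gives an at least 8.0-fold higher number from compound 3 to compound 4 (0.90 log units; beyond the scatter), so a side chain carrying a six-membered ring need not stay low, although compound 2 and compound 3 do. The larger step is an at least 62-fold higher number from compound 2 to compound 4 (1.79 log units; beyond the scatter), with 3-((4-hydroxycyclohexyl)amino)propyl in place of 1-(2-hydroxy-2-methylpropyl)piperidin-4-yl on an oxygen on an aromatic ring.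

On these data alone, the step between compound 1 and compound 4 cannot be read, and the true number for compound 4 remains unknown. As far as these compounds go, the hydroxyl, the carbon-only ring and the chain length all change together here, so their shares stay open; a plain cyclohexylamino group or a morpholine on the same propoxy chain would separate them.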